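Diaryl ureas on an aminopyridine core: cytotoxicity notes

The source may report more compounds than this note shows. Statements on the series, on what has been measured and on what is new or still open speak of the compounds shown alone.

Measured in a functional assay on MCF7 cells (Homo sapiens) for cytotoxicity, read by MTT assay, with a stated time of 24 h; on this read-out lower numbers stand for stronger inhibition and higher numbers for weaker inhibition:
- compound 1 `CCNc1cc(-c2ccc(NC(=O)Nc3cccc(Cl)c3)cc2F)ccn1` gives 6940 nM
- compound 2 `CCNc1cc(-c2ccc(NC(=O)Nc3ccc(C(F)(F)F)cc3)cc2F)ccn1` gives 8020 nM
- compound 3 `O=C(Nc1cccc(Cl)c1)Nc1ccc(-c2ccnc(NCC3CC3)c2)c(C(F)(F)F)c1` gives 17400 nM

Compound 1 and compound 2 share one core and differ only by 4-(trifluoromethyl)phenyl in place of 3-chlorophenyl on an amide-type nitrogen. In this assay this change gives a 1.2-fold higher number from compound 1 to compound 2 (0.06 log units; within the scatter), so the two numbers cannot be told apart.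

Compound 3 carries a different core; the difference between the two cores is not broken down here. Its number in this assay is the highest of the three, beyond the scatter from compound 2 and from compound 1.

Compound 4 `O=C(Nc1ccc(C(F)(F)F)cc1)Nc1ccc(-c2ccnc(NCC3CC3)c2)c(C(F)(F)F)c1` is not yet measured. It differs from compound 3 by 4-(trifluoromethyl)phenyl in place of 3-chlorophenyl on an amide-type nitrogen, the same change as from compound 1 to compound 2, at the same place. That earlier step stayed within the scatter, so compound 4 is expected to sit near compound 3 in this assay: an expected step of a 1.1-fold higher number from compound 3 to compound 4 (0.06 log units; within the scatter), resting on a 1.2-fold higher number from compound 1 to compound 2 (0.06 log units; within the scatter). The estimate for compound 4 is 20000 nM, expected between 10000 nM and 40000 nM.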

Compound 4, half-maximal inhibitory concentration: 15600 nM
The estimate for compound 4 lay 1.3-fold (0.11 log units) above the measured number; low and high end bracket the measured number.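

In this assay, putting 4-(trifluoromethyl)phenyl in place of 3-chlorophenyl on an amide-type nitrogen gives a 1.1-fold lower number from compound 3 to compound 4 (0.05 log units; within the scatter), so compound 3 and compound 4 cannot be told apart on this read-out. On both cores the change leaves no readable step, and the two steps do not differ: the same change on two cores in this assay, a 1.2-fold higher number (0.06 log units; within the scatter) from compound 1 to compound 2 and a 1.1-fold lower number (0.05 log units; within the scatter) from compound 3 to compound 4, 1.3-fold (0.11 log units) apart, within the scatter of two such steps. For the compounds shown here, this shows that the change carries over between these two cores as a silent one, but it rests on only two pairs and does not show that the same would hold on any further core, or that the two groups are interchangeable in any other assay.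

Still open, on these data alone, is whether a phenyl ring carrying an amine or a carboxylic acid, or a plain alkyl chain in place of the ring, would also leave the number undisturbed on this amide-type nitrogen. The compounds shown also do not separate the places in which the two cores differ, so what sets compound 3 and compound 4 apart from compound 1 and compound 2 remains unassigned.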